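The source may hold more compounds than are shown below. What is called first, only, known or untested is meant among the compounds shown, and "the series" means these compounds.

Of the compounds shown here, three sharing one core have been tested in an ADME assay on MT4 cells (Homo sapiens) for cytotoxicity, read by MTT assay, with a stated time of 4 days; a higher number here means that more compound is tolerated, a lower number that less compound is tolerated: compound 1 `Cc1ccc(OCCn2ccc(=O)n(Cc3ccccc3C)c2=O)cc1`, compound 2 `Cc1ccc(OCCn2ccc(=O)n(Cc3cccc(C)c3)c2=O)cc1` and compound 3 `Cc1ccc(OCCn2ccc(=O)n(Cc3cc(C)ccc3C)c2=O)cc1`. Going by the values given here, compound 1 gives 46000 nM, the only exact number of the three. Compound 2 gives >= 38000 nM, which is a limit of the assay. Compound 3 gives > 343000 nM, which is also a limit, so its standing is known only as a limit.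

The compound still to be measured, compound 4 `Cc1ccc(OCCn2ccc(=O)n(Cc3cc(C)cc(C)c3)c2=O)cc1`, differs from compound 3 as follows: 3,5-dimethylphenyl in place of 2,5-dimethylphenyl on a saturated chain carbon bound to an aromatic nitrogen. Here 3,5-dimethylphenyl stands in place of 2,5-dimethylphenyl on a saturated chain carbon bound to an aromatic nitrogen.

Among the compounds with values here, only one measured step bears on this with a readable size: an at least 7.4-fold higher number from compound 1 to compound 3 (0.87 log units; beyond the scatter), with methyl in place of hydrogen on an aromatic carbon. The other two give no size: a step that the limit leaves unreadable from compound 1 to compound 2, and a step that the two limits leave unreadable from compound 2 to compound 3. Compound 4 gives up the 2,5-dimethylphenyl group that ended the readable step of an at least 7.4-fold higher number from compound 1 to compound 3 (0.87 log units; beyond the scatter), so that gain is not expected to carry over in full. The expected change in this assay is an at least 3.4-fold lower number from compound 3 to compound 4 (0.53 log units; beyond the scatter), towards a lower number, and its size is uncertain. For compound 4 the estimate is 100000 nM, with an expected range from 30000 nM to 350000 nM.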

Compound 4, half-maximal cytotoxic concentration: > 343000 nM
Compound 4 gave a limit, no number; the forecaster's own chance of this, stated with the estimate: 45%; at least 3.4-fold (0.53 log units) between middle value and limit.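

In this assay compound 4 gives > 343000 nM, which is a limit of the assay and not a number. With 3,5-dimethylphenyl on a saturated chain carbon bound to an aromatic nitrogen, the record shows an at least 7.4-fold higher number from compound 1 to compound 4 (0.87 log units; beyond the scatter), so the readable gain at this place is no longer tied to 2,5-dimethylphenyl alone. The steps to compound 4 from compound 2 and from compound 3 cannot be read, because the values involved are limits, and compound 3 and compound 4 share the same one: the limit of > 343000 nM in this assay, at which 2 of the 4 values shown sit.

As far as these compounds go, how much compound is really tolerated for compound 3 and for compound 4 stays open, and no order between these two can be given. From the compounds shown here alone, it also stays open how this assay would read with a phenyl carrying an amine or a carboxylic acid in place of the dimethylphenyl group, or with a longer chain joining that ring to the shared core.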